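The compounds below may be only part of what the source reports. "The series", "measured", "known", "first", "only" and "open" are said of these compounds alone.

Compound 1 `NS(=O)(=O)c1ccc(-c2nc(C(c3ccc(F)cc3)c3ccc(F)cc3)sc2CC(=O)O)cc1`: 1500 nM
Compound 2 `O=C(O)Cc1sc(C(c2ccc(F)cc2)c2ccc(F)cc2)nc1-c1cn[nH]c1`: 16 nM

Among the measured compounds shown here, in an in vitro assay on HEK385-7 cells for displacement of a labelled ligand from prostaglandin D2 receptor 2 (Homo sapiens) (on this read-out lower numbers stand for stronger inhibition and higher numbers for weaker inhibition), compound 2 holds the lowest of the two numbers, and the single measured step, a 94-fold lower number from compound 1 to compound 2 (1.97 log units; beyond the scatter), shows how strongly the group at this position can move the read-out. Compound 3 `Cc1cc(-c2nc(C(c3ccc(F)cc3)c3ccc(F)cc3)sc2CC(=O)O)ccn1` is not yet measured; it differs from compound 2 by 2-methylpyridin-4-yl in place of 1H-pyrazol-4-yl on an aromatic carbon. For the measured compounds named here, only that one step bears on this change, and the entering group carries 0 hydrogen-bond donors where the leaving group carried 1, so a shift toward weaker inhibition is expected, though smaller than that step. Compound 3 is expected to give 150 nM, between 30 nM and 800 nM. The expected step is a 9.4-fold higher number from compound 2 to compound 3 (0.97 log units; beyond the scatter).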

Compound 3, half-maximal inhibitory concentration: 3.1 nM
The estimate for compound 3 lay 48-fold (1.68 log units) above the measured number; the whole stated range lies above it.
By their numbers in this assay, from the lowest: compound 3; then compound 2; then compound 1.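

In this assay, 2-methylpyridin-4-yl in place of 1H-pyrazol-4-yl gives a 5.2-fold lower number from compound 2 to compound 3 (0.71 log units; beyond the scatter), so a hydrogen-bond donor on this group is not required for a low number at this position. The same group in place of 4-sulfamoylphenyl gives a 480-fold lower number from compound 1 to compound 3 (2.68 log units; beyond the scatter), which shows that a six-membered aromatic ring here is compatible with a low number. Nothing available explains either step. The compounds shown leave open what the methyl group itself contributes, which a plain pyridin-4-yl would test, and whether an amine or a methoxy group in its place would keep the number low.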